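The source may hold more compounds than are shown below. What is called first, only, known or untested is meant among the compounds shown, and "the series" means these compounds.

Compound 1 `COc1cc(/C=C/C(=O)/C=C(O)/C=C/c2ccc(OC(=O)C(C)NC(=O)OCc3ccccc3)c(OC)c2)ccc1OC(=O)C(C)NC(=O)OCc1ccccc1` carries the same chain twice, each drawn without a configuration at its saturated chain carbon. In a functional assay on the whole organism (strain Wistar) for inhibition, with Rattus norvegicus as the target, read by paw edema, with stated times of 1 h and 3 h, at a dose of 10 mg/kg by the intraperitoneal route (a higher number here means more inhibition at the dose given (going by the name of the read-out), a lower number less inhibition), compound 1 gives 97%. Compound 2 `COc1cc(/C=C/C(=O)/C=C(O)/C=C/c2ccc(OC(=O)[C@@H](C)NC(=O)OCc3ccccc3)c(OC)c2)ccc1OC(=O)[C@@H](C)NC(=O)OCc1ccccc1` has the same atoms and bonds, but both of those stereocentres are drawn R, and in this assay compound 2 gives 95%. The step of a number 2 percentage points lower from compound 1 to compound 2 (within the scatter) is the only one measured, and it is within the scatter; the two compounds differ only in that one of them is drawn with a defined configuration and the other without (the fact that one of compounds 1 and 2 is drawn with a defined configuration and the other without, at the place where they differ). On the numbers shown, compound 2 thus sits beside compound 1, with nothing between them beyond the scatter.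

Compound 3 `COc1cc(/C=C/C(=O)/C=C(O)/C=C/c2ccc(OC(=O)[C@H](C)NC(=O)OCc3ccccc3)c(OC)c2)ccc1OC(=O)[C@H](C)NC(=O)OCc1ccccc1` is the mirror form at those two centres: the two compounds have the same atoms and bonds and differ only in configuration as drawn: 2 of 5 stereo elements differ; a stereocentre at a saturated chain carbon is drawn R in compound 2 and S in compound 3; a stereocentre at a saturated chain carbon is drawn R in compound 2 and S in compound 3. For the measured compounds named here, the single step that bears on this change, the one from an undefined drawing to the R form, was small. Since drawing the centres R changed nothing beyond the scatter, the estimated step of a number 2 percentage points lower from compound 2 to compound 3 (within the scatter) is expected to stay within the scatter too. For compound 3 the expected value is 93%, with a range from 80% to 99%.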

Compound 3, a percentage reported as inhibition, in the whole organism at one dose (the size of the read-out at that dose, not a potency): 22%
Estimate against measurement, compound 3: 71 percentage points above; measured number below the stated range.
By their numbers in this assay, from the lowest: compound 3; then compounds 2 and 1 (each within the scatter of the next).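

The configuration at these two saturated chain carbons matters a great deal in this assay, with a number 73 percentage points lower from compound 2 to compound 3 (beyond the scatter), and the comparison with the form drawn without a configuration gives a number 75 percentage points lower from compound 1 to compound 3 (beyond the scatter). The earlier step from the undefined drawing to the R form stayed within the scatter and gave no sign of this sensitivity, which appears only once the S form is set against the other two. This pair has the same atoms and bonds, so the large step can be traced to the handedness of the two centres alone: the fact that compounds 2 and 3 differ only in the configuration as drawn.

Both centres change together in these compounds, so they leave open whether one centre alone would account for the drop or whether both S centres are needed, and a form with one R and one S centre would bear on this. They also leave open whether the same preference would hold with an isopropyl group in place of the methyl on that carbon or a free amine in place of the benzyl carbamate, and why a whole-animal read-out responds so differently to the two mirror forms.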